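Fluoro in place of hydrogen on compound 1

This account rests on a few compounds, and the source may have more. Where it says the series, first, only, none or still open, it means among the compounds named here.

Measured so far in an ADME assay on MT4 cells (Homo sapiens) for cytotoxicity; on this read-out higher numbers stand for lower toxicity in this test and lower numbers for higher toxicity in this test:
- compound 1 (`Cc1cc(C)cc(S(=O)(=O)n2c(=O)[nH]c3ccc(Cl)cc32)c1`) gives 39000 nM
- compound 2 (`Cc1cc(C)cc(S(=O)(=O)n2c(=O)[nH]c3ccc(C)cc32)c1`) gives > 308000 nM as a limit of the assay
- compound 3 (`Cc1ccc2[nH]c(=O)n(Cc3cc(F)cc(F)c3)c2c1`) gives 73000 nM

For the measured compounds named here, compound 1 stands within the scatter of compound 3, and these two hold the only exact numbers. Compound 2 is known only as a limit.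

Compound 4 (`Cc1cc(C)cc(S(=O)(=O)n2c(=O)[nH]c3cc(F)c(Cl)cc32)c1`) is the next point. The difference fluoro in place of hydrogen on an aromatic carbon is fluoro in place of hydrogen on an aromatic carbon, and the chloro group of compound 1 stays.

Going by the values given here, only one measured step bears on this, and only indirectly. In an at least 7.8-fold higher number from compound 1 to compound 2 (0.89 log units; beyond the scatter) the change is methyl in place of chloro, beyond the scatter. Among the compounds with values here, it shows that one group on the shared core can move the number in this assay, but compound 4 keeps the chloro group and no measured step covers fluoro in place of hydrogen. Compound 4 is therefore expected to stay close to compound 1 at 39000 nM.

The estimated step is a 1.2-fold lower number from compound 1 to compound 4 (0.09 log units; within the scatter) and is expected to stay within the scatter, with no firm direction. Compound 4 is estimated at 32000 nM, with an expected range from 12000 nM to 80000 nM.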

Compound 4, half-maximal cytotoxic concentration: 140000 nM
Compound 4: the middle estimate sits 4.4-fold (0.64 log units) below what was measured, outside the stated range (above it).
By their numbers in this assay, from the lowest: compounds 1, 3 and 4 (each within the scatter of the next, the first and the last beyond it). At a limit, above all of these: compound 2.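

In this assay, fluoro in place of hydrogen on the aromatic carbon ortho to a chloro group gives a 3.6-fold higher number from compound 1 to compound 4 (0.56 log units; beyond the scatter), so the number on the shared core responds at this position while the chloro group stays in place. Among the earlier compounds, the only measured step on this core replaced the chloro group itself and gave an at least 7.8-fold higher number from compound 1 to compound 2 (0.89 log units; beyond the scatter); the new step shows that a higher number, meaning lower toxicity in this test, does not require losing the chloro group. The sizes of the two steps cannot be set against each other, as compound 2 is known only as a limit of the assay: the limit of > 308000 nM in this assay, at which 1 of the 4 values shown sits.

As far as these compounds go, it remains open whether another group on this aromatic carbon, such as an amine, a methoxy group or a carboxylic acid, would move the number in the same direction as fluoro. From the compounds shown here alone, it also remains open whether fluoro at this position would have a comparable effect with a methyl group in place of the chloro group.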